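The source may report more compounds than this note shows. Statements on the series, on what has been measured and on what is new or still open speak of the compounds shown alone.

Of the compounds shown here, three built on one shared core have been tested in a functional assay on MCF7 cells (Homo sapiens) for antiproliferative activity, read by MTT assay, with a stated time of 72 h; a higher number here means a weaker inhibitor, a lower number a stronger inhibitor. Compound 2 `FC(F)(F)c1ccc(COc2cccc(Nc3ncnc4cc5c(cc34)OCCOCCOCCO5)c2)cc1` gives 17600 nM in this assay, the lowest of the two numbers recorded. Compound 1 `O=[N+]([O-])c1ccc(COc2ccc(Nc3ncnc4cc5c(cc34)OCCOCCO5)cc2)cc1` gives 39700 nM in this assay, a number that sits beyond the usual scatter from that of compound 2. Compound 3 `c1ccc(COc2ccccc2Nc2ncnc3cc4c(cc23)OCCOCCO4)cc1` reaches only a limit of this assay, recorded as > 100000 nM rather than as a number. Of the three values, one is therefore (the limit of > 100000 nM in this assay, at which 1 of the 3 values shown sits).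

Compound 4 `c1ccc(COc2cccc(Nc3ncnc4cc5c(cc34)OCCOCCOCCO5)c2)cc1` is the compound still to be measured. It differs from compound 2 in one place: hydrogen in place of trifluoromethyl on an aromatic carbon. Among the measured compounds shown here, no measured pair shows this same change on its own, so the size of the step can only be judged from the surroundings. Compound 2, carrying trifluoromethyl, gives the lowest number; compound 1, carrying a nitro group instead, gives a higher one; compound 3, carrying a plain benzyl but also a differently placed amine and a shorter linker, reaches only the limit. Taken together, the change is expected to weaken the compound, with the step from compound 2 to compound 4 estimated at a 2.0-fold higher number from compound 2 to compound 4 (0.30 log units; within the scatter), beyond the scatter. Compound 4 is therefore expected to give about 35000 nM in this assay, within a range from 12000 nM to 100000 nM.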

Compound 4, half-maximal inhibitory concentration: > 100000 nM
Compound 4 ended at the assay's limit; the forecaster's own chance of this, stated with the estimate: 20%; middle value at least 2.8-fold (0.45 log units) away from the limit.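

Taking the trifluoromethyl group off the 4-(trifluoromethyl)benzyl of compound 2, leaving hydrogen on that aromatic carbon, is the first change here that can be read on its own, and in this assay it gives an at least 5.6-fold higher number from compound 2 to compound 4 (0.75 log units; beyond the scatter). This step is only a lower bound: compound 4 stands at a limit of the assay, so the pair shows a clear loss but not its full size. Within this pair, a measurable number is kept only with trifluoromethyl at this place, and a plain benzyloxy group does not keep it, so the limit is no longer a single case: the limit of > 100000 nM in this assay, at which 2 of the 4 values shown sit.

On these data alone, what stays open is whether trifluoromethyl itself matters or whether other groups on the same aromatic carbon would serve as well, which a chlorine atom, a methoxy group or a nitrile there would begin to separate. Also open, as far as these compounds go, is whether an amine or a carboxylic acid at this place would give a number below the limit, and with it a step of readable size.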